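This account rests on a few compounds, and the source may have more. Where it says the series, first, only, none or still open, it means among the compounds named here.

Compound 2 `Cc1cc(-c2sc(Cc3cccc(Cl)c3)nc2C)ccc1C(N)=O` carries a chloro group on its pendant ring and gives 75% in a functional assay on cells for agonist activity at G-protein coupled receptor 52 (Homo sapiens), read by AlphaScreen and cAMP accumulation, with a stated time of 30 min; on this read-out higher numbers stand for larger maximal responses and lower numbers for smaller maximal responses. Compound 1 `Cc1cc(-c2sc(Cc3cccc(C(F)(F)F)c3)nc2C)ccc1C(N)=O` gives 86% in this assay; it differs from compound 2 by trifluoromethyl in place of chloro on an aromatic carbon, and this change brings a number 11 percentage points higher from compound 2 to compound 1 (beyond the scatter). Compound 3 `Cc1cc(-c2sc(Cc3cc(F)cc(Cl)c3)nc2C)ccc1C(N)=O` instead differs from compound 2 by fluoro in place of hydrogen on an aromatic carbon, with a number 13 percentage points higher from compound 2 to compound 3 (beyond the scatter), so that compound 3 and compound 1 stand within the scatter of each other in this assay.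

Compound 4 `Cc1cc(-c2sc(Cc3cc(F)cc(C(F)(F)F)c3)nc2C)ccc1C(N)=O` has not been measured. It differs from compound 3 by trifluoromethyl in place of chloro on an aromatic carbon, the same kind of change as from compound 2 to compound 1, though here the place is also meta to a fluoro group. Because compound 3 already gives 88%, only a small step is expected in this assay, a number 4 percentage points higher from compound 3 to compound 4 (within the scatter), so that compound 4 is estimated at 92%, between 80% and 104%.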

Compound 4, largest response reached (Emax), in percent of the reference or control that the assay uses: 93%
Compound 4: middle estimate off by 1 percentage points, on the low side; low and high end bracket the measured number.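

In this assay, trifluoromethyl in place of chloro gives a number 5 percentage points higher from compound 3 to compound 4 (within the scatter), and this step compares with the earlier one as follows: the same change on two cores in this assay, a number 11 percentage points higher (beyond the scatter) from compound 2 to compound 1 and a number 5 percentage points higher (within the scatter) from compound 3 to compound 4, 6 percentage points apart, within the scatter of two such steps. Fluoro in place of hydrogen gives a number 7 percentage points higher from compound 1 to compound 4 (within the scatter), and the comparison is similar: the same change on two cores in this assay, a number 13 percentage points higher (beyond the scatter) from compound 2 to compound 3 and a number 7 percentage points higher (within the scatter) from compound 1 to compound 4, 6 percentage points apart, within the scatter of two such steps. Neither change differs measurably between the two cores, but each new step lies within the scatter on its own, and a single pair of steps per change does not show that either would carry over to other cores.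

All four compounds carry chloro or trifluoromethyl at this place, leaving open what a nitrile, a methoxy group or an amine there would give. Also open, on these data alone, is what a carboxylic acid in place of the shared amide would give in this assay.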